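A few compounds are considered here, and "the series" means these few. Any claim that something is new, unique, unknown or untested is made for them only; others in the source may bear on it.

Measured compounds: compound 1 `CS(=O)(=O)c1ccc(Nc2ncc(F)c(Nc3nc4ccc(Cl)cc4s3)n2)cc1`, compound 2 `CS(=O)(=O)c1ccc(Nc2nccc(Nc3nc4ccc(Cl)cc4s3)n2)cc1` and compound 3 `NS(=O)(=O)c1ccc(Nc2nccc(Nc3nc4ccccc4s3)n2)cc1`.

In a functional assay on MCF7 cells (Homo sapiens) for antiproliferative activity, read by MTT assay, with a stated time of 48 h (a higher number here means a weaker inhibitor, a lower number a stronger inhibitor), compound 1 gives only a limit, > 50000 nM. In this assay compound 2 likewise gives only a limit, > 50000 nM. Among the compounds with values here, compound 3 is the one measured compound with a number, 15300 nM in this assay. The difference between the core of compound 3 and the core of compound 2 is not broken down here.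

From compound 2 to compound 1 the change is fluoro in place of hydrogen on an aromatic carbon, and the step that the two limits leave unreadable from compound 2 to compound 1 cannot be read, because the limit of > 50000 nM in this assay, at which 2 of the 3 values shown sit, holds both ends. Compound 4 `NS(=O)(=O)c1ccc(Nc2nccc(Nc3nc4ccc(F)cc4s3)n2)cc1`, not yet measured, carries the same kind of change from compound 3, (fluoro in place of hydrogen on an aromatic carbon), but not the same one: here the place is a six-membered aromatic ring of carbon only within a fused system, meta and para to a fused ring, rather than a ring with two nitrogen.

From compound 3 the expected step is estimated as a 1.3-fold higher number from compound 3 to compound 4 (0.12 log units; within the scatter), set beside the unreadable step that the two limits leave unreadable from compound 2 to compound 1. Compound 4 is expected to give about 20000 nM in this assay, between 7000 nM and 60000 nM.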

Compound 4, half-maximal inhibitory concentration: 10900 nM
Compound 4: middle estimate off by 1.8-fold (0.26 log units), on the high side; the measured number falls inside the stated range.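

Set on the core of compound 3, fluoro in place of hydrogen on an aromatic carbon of a six-membered aromatic ring of carbon only gives, in this assay, a 1.4-fold lower number from compound 3 to compound 4 (0.15 log units; within the scatter) and so leaves compound 3 and compound 4 indistinguishable on this read-out. This shows only that, at this place on this core, the change has no effect that can be told from the scatter; it does not show that the same holds at another place or on another core. The matching step on the core of compound 2 cannot be read, so the two steps cannot be compared, because compound 1 and compound 2 give only limits: the limit of > 50000 nM in this assay, at which 2 of the 4 values shown sit.

The compounds shown leave open how a larger group, such as methoxy or an amine, would read at the place of the fluoro on the core of compound 3. They also leave open whether fluoro gives a readable step on any core that yields numbers at both ends.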